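A Trifluoromethyl Chain End and Cell Toxicity

The source may hold more compounds than are shown below. What is called first, only, known or untested is meant among the compounds shown, and "the series" means these compounds.

In an ADME assay on Huh-7 cells (Homo sapiens) for cytotoxicity, with a stated time of 72 h (on this read-out lower numbers stand for higher toxicity in this test and higher numbers for lower toxicity in this test), compound 2 `CC(C)CCc1nn(CCC(C)C)c(=O)c(C2=NS(=O)(=O)c3cc(NS(C)(=O)=O)ccc3N2)c1O` gives > 33000 nM as a limit of the test, not a number. Compound 1 `CC(C)CCn1nc(-c2ccn(C)c2)c(O)c(C2=NS(=O)(=O)c3cc(NS(C)(=O)=O)ccc3N2)c1=O` gives > 1000 nM and this too is only a limit. Compound 3 `CC(C)CCn1nc(CCC(F)(F)F)c(O)c(C2=NS(=O)(=O)c3cc(NS(C)(=O)=O)ccc3N2)c1=O` has trifluoromethyl in place of isopropyl on a saturated chain carbon, two bonds along the chain from an aromatic carbon. Among the measured compounds shown here, since the one measured step that the two limits leave unreadable from compound 1 to compound 2 has no readable size, no shift beyond the scatter is expected in this assay for this change. The expected step of a number no higher from compound 2 to compound 3 (the limit leaves the size open) should therefore stay small. Compound 3 is estimated at 33000 nM and expected between 10000 nM and 100000 nM in this test.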

Compound 3, half-maximal cytotoxic concentration: > 33000 nM
Compound 3 was reported as a limit; the forecaster's own chance of this, stated with the estimate: 80%; the middle value sits exactly at the limit.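

Among the compounds shown here, compound 1, compound 2 and compound 3 are all reported only as limits of the test, and no step between them can be read. The compounds shown leave open each one's true cytotoxic concentration, and whether trifluoromethyl in place of isopropyl changes it at all.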